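Swapping the side aryl ring on the shared core

A few compounds are considered here, and "the series" means these few. Any claim that something is new, unique, unknown or untested is made for them only; others in the source may bear on it.

Compound 3 `CS(=O)(=O)c1ccc(-c2oc3ccccc3c(=O)c2-c2ccc(Cl)cc2)cc1` was tested in an assay on isolated protein for inhibition of prostaglandin G/H synthase 1 (Mus musculus), tested at 10 ug/mL; a higher number here means more inhibition at the concentration tested (going by the name of the read-out), a lower number less inhibition. In this assay compound 3 gives only a limit, < 5%, not a number. Compound 4 `Cc1ccccc1-c1c(-c2ccc(S(C)(=O)=O)cc2)oc2ccccc2c1=O` has not been measured yet; it differs from compound 3 by 2-methylphenyl in place of 4-chlorophenyl on an aromatic carbon. Within the data shown here, the only measured single-point comparison runs from compound 1 `NS(=O)(=O)c1ccc(-c2oc3ccccc3c(=O)c2-c2ccccc2)cc1` to compound 2 `COc1ccc(-c2c(-c3ccc(S(N)(=O)=O)cc3)oc3ccccc3c2=O)cc1`. In this assay compound 1 gives 61% and compound 2 gives 84%. That step is a number 23 percentage points higher from compound 1 to compound 2 (beyond the scatter). It alters a different group on a different ring, so it says little about the change into compound 4. Compound 3 sits at the limit (the limit of < 5% in this assay, at which 1 of the 3 values shown sits). The step of a number at least 5 percentage points higher from compound 3 to compound 4 (that floor lies within the scatter) is therefore expected to be small. Compound 4 is estimated at 10%, within 0% to 35%.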

Compound 4, a percentage reported as inhibition, at one concentration (the size of the read-out at that concentration, not a potency): < 5%
Compound 4 ended at the assay's limit; the forecaster's own chance of this, stated with the estimate: 50%; middle value at least 5 percentage points from the limit.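

In this assay compound 3 and compound 4 both give only a limit, not a number, so no step between them can be read: the limit of < 5% in this assay, at which 2 of the 4 values shown sit.

On these data alone, whether 2-methylphenyl or 4-chlorophenyl gives more inhibition on the shared core stays open.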